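Aryl substituent exchange in the lactone series: compound 4

The compounds below may be only part of what the source reports. "The series", "measured", "known", "first", "only" and "open" are said of these compounds alone.

For the measured compounds named here, compound 3 `C=C1C(=O)O[C@@H](C)[C@@H]1c1ccc(Br)cc1` is the strongest of the three measured so far. In a functional assay on L1210 cells (Mus musculus) for cytotoxicity, read by MTT assay, with a stated time of 48 h (on this read-out higher numbers stand for weaker inhibition and lower numbers for stronger inhibition), compound 3 gives 580 nM. Its nearest neighbour on the numbers is compound 1 `C=C1C(=O)OC(C)CC1c1ccc([N+](=O)[O-])cc1`, which in this assay gives 1200 nM; the furthest is compound 2 `C=C1C(=O)O[C@H](C)[C@@H]1c1ccc(Br)cc1`, which in this assay gives 7800 nM. Going by the values given here, the only single-point step measured is a 13-fold lower number from compound 2 to compound 3 (1.13 log units; beyond the scatter), which rests on (the fact that compounds 2 and 3 differ only in the configuration as drawn). Compound 4 `C=C1C(=O)O[C@@H](C)[C@@H]1c1ccc(C)cc1` differs from compound 3 in methyl in place of bromo on an aromatic carbon. Among the compounds with values here, no measured step changes the group on the aromatic ring while everything else is held fixed; compound 1 carries a different group on that ring and its configuration is not drawn, so its comparison with compound 3 shows only that the two numbers lie a little apart. The stereo step from compound 2 to compound 3 does not bear on the present change. For compound 4 a small step is expected, a 1.6-fold higher number from compound 3 to compound 4 (0.19 log units; within the scatter), lying within or close to the scatter. Compound 4 is expected to give 900 nM in this assay, with a range from 350 nM to 2500 nM.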

Compound 4, half-maximal inhibitory concentration: 1500 nM
Beside the measured number, compound 4's estimate is 1.7-fold (0.22 log units) below it; low and high end bracket the measured number.
By their numbers in this assay, from the lowest: compound 3; then compounds 1 and 4 (each within the scatter of the next); then compound 2.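

The position on the aromatic ring now has its first clean reading: with the configuration and the rest of the core held fixed, methyl in place of bromo gives a 2.6-fold higher number from compound 3 to compound 4 (0.41 log units; beyond the scatter) in this assay. So the exchange at this position moves the number beyond the scatter, though by less than the configuration change in a 13-fold lower number from compound 2 to compound 3 (1.13 log units; beyond the scatter) within these two pairs. Nothing at hand bears on why this exchange moves the number.

Only bromo and methyl can be compared directly here, and the nitro group of compound 1 gives no clean third point, as its configuration is not drawn. As far as these compounds go, it remains open how an amine, a carboxylic acid or a longer chain at this position would read, and whether the bromo-to-methyl step holds in the configuration of compound 2.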